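Swapping the Heteroaryl Amide Partner in a p300 Inhibitor

This account rests on a few compounds, and the source may have more. Where it says the series, first, only, none or still open, it means among the compounds named here.

Of the compounds shown here, three have been measured in an assay on isolated protein for inhibition of histone acetyltransferase p300 (Homo sapiens), with a stated time of 60 min; a lower number here means a stronger inhibitor, a higher number a weaker inhibitor. Compound 1 `COc1ccc(NC(=O)[C@H]2CCCN2C(=O)C(C)(C)c2ccc(Cl)cc2)cc1` gives 50.1 nM, compound 2 `COc1ccc(NC(=O)[C@H]2CCCN2C(=O)C2(c3ccc(Cl)cc3)CCCC2)cc1` gives 7.94 nM, and compound 3 `O=C(Nc1ccc2[nH]ncc2n1)[C@H]1CCCN1C(=O)C1(c2cccc(Cl)c2)CCCC1` gives 0.159 nM, the lowest of the three numbers and set apart from both others by more than the usual scatter. Compound 4 `CNC(=O)c1ccc(NC(=O)[C@H]2CCCN2C(=O)C2(c3cccc(Cl)c3)CCCC2)cc1` has not yet been measured. It differs from compound 3 in one place: a group of 10 heavy atoms (8 carbon, 1 nitrogen, 1 oxygen; one six-membered aromatic ring of carbon only) in place of a group of 9 heavy atoms (6 carbon, 3 nitrogen; one five-membered aromatic ring with 2 hetero atoms, one six-membered aromatic ring with 1 hetero atom), on an amide-type nitrogen. Within the data shown here, no measured pair shows this exact change, so the size of the step is uncertain. The group that leaves accompanies the strong result of compound 3 at 0.159 nM, and the step from compound 3 to compound 4 is expected to be a weakening one, estimated at a 19-fold higher number from compound 3 to compound 4 (1.28 log units; beyond the scatter). For compound 4 the expected value in this assay is 3 nM, within a range from 0.8 nM to 15 nM.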

Compound 4, half-maximal inhibitory concentration: 0.794 nM
The estimate for compound 4 lay 3.8-fold (0.58 log units) above the measured number; the measured number lies below the stated range.
By their numbers in this assay, from the lowest: compound 3; then compound 4; then compound 2; then compound 1.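

In this assay, putting 4-(methylcarbamoyl)phenyl in place of the two-ring heteroaryl group on the amide-type nitrogen gives a 5.0-fold higher number from compound 3 to compound 4 (0.70 log units; beyond the scatter), a real but modest loss. The two-ring group is therefore not essential for strong inhibition, since a single carbon-only aromatic ring still leaves compound 4 at 0.794 nM. Nothing available here explains the size of this step. The compounds shown leave open what part the methyl group of the methylcarbamoyl substituent plays. A primary amide or a carboxylic acid in its place could test this.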